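Methyl for methoxy on the pendant aryl ring of compound 3

A few compounds are considered here, and "the series" means these few. Any claim that something is new, unique, unknown or untested is made for them only; others in the source may bear on it.

Three compounds of the series carry the same core and differ only in the aryl group on the saturated chain carbon bound to the amide-type nitrogen in the ring. In a functional assay on SH-SY5Y cells (Homo sapiens) for cytotoxicity, read by MTT assay, with stated times of 8 h, 30 min and 12 h, tested at 0.05 uM (a lower number here means a weaker effect, a higher number a stronger effect of the compound at the concentration tested), compound 1 `N=C(NCc1ccc(O)cc1)[C@@H]1CCC(=O)N1Cc1ccccc1[N+](=O)[O-]` gives 20%. Compound 2 `N=C(NCc1ccc(O)cc1)[C@@H]1CCC(=O)N1Cc1ccc([N+](=O)[O-])cc1` gives 25.9% in this assay, and the move to 4-nitrophenyl in place of 2-nitrophenyl reads a number 5.9 percentage points higher from compound 1 to compound 2 (within the scatter). Compound 3 `COc1ccc(CN2C(=O)CC[C@H]2C(=N)NCc2ccc(O)cc2)cc1` gives 16% in this assay; from the 2-nitrophenyl analogue the step is a number 4 percentage points lower from compound 1 to compound 3 (within the scatter) and from the 4-nitrophenyl analogue a number 9.9 percentage points lower from compound 2 to compound 3 (within the scatter). Compound 3 therefore stands together with compound 1 and compound 2, every step among the three being within the scatter.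

Compound 4 `Cc1ccc(CN2C(=O)CC[C@H]2C(=N)NCc2ccc(O)cc2)cc1` differs from compound 3 by methyl in place of methoxy on an aromatic carbon. Going by the values given here, no measured pair exchanges methoxy for methyl; the nearest precedent is the methoxy-for-nitro step a number 9.9 percentage points lower from compound 2 to compound 3 (within the scatter), and the two aryl swaps a number 5.9 percentage points higher from compound 1 to compound 2 (within the scatter) and a number 4 percentage points lower from compound 1 to compound 3 (within the scatter), all of which stayed within the scatter. On that basis no step beyond the scatter in this assay is expected here, and the estimated step is a number 1 percentage points higher from compound 3 to compound 4 (within the scatter). For compound 4 the expected value in this assay is 17%, with a range from 8% to 28%.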

Compound 4, a percentage reported as activity, at one concentration (the size of the read-out at that concentration, not a potency): 20.5%
Compound 4: the middle estimate sits 3.5 percentage points below what was measured, and the stated range covers the measured number.
By their numbers in this assay, from the lowest: compounds 3, 1, 4 and 2 (each within the scatter of the next).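

In this assay, the change from 4-methoxyphenyl to 4-methylphenyl removes the oxygen and its hydrogen-bond acceptor from this ring substituent and gives a number 4.5 percentage points higher from compound 3 to compound 4 (within the scatter). The position therefore now carries a simple carbon-only group as well as methoxy and nitro, with no step beyond the scatter among the compounds shown. Against the nitro analogues, the methyl compound gives a number 5.4 percentage points lower from compound 2 to compound 4 (within the scatter) and a number 0.5 percentage points higher from compound 1 to compound 4 (within the scatter), so the first direct comparisons of methyl with nitro also leave the four aryl variants of the shared core unresolved in this read-out, and no information is available to explain these numbers.

Going by these compounds, it remains open whether an amine or a carboxylic acid on this aromatic carbon would produce a step beyond the scatter, or whether a longer chain such as propyl in place of methyl would do so. On these data alone, it also remains open whether the four compounds would stay this close at concentrations other than the single one tested here.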